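The source may report more compounds than this note shows. Statements on the series, on what has been measured and on what is new or still open speak of the compounds shown alone.

Measured so far in an ADME assay on HEp-2 cells (Homo sapiens) for cytotoxicity, read by trypan blue exclusion, with a stated time of 24 h; a lower number here means that less compound is tolerated, a higher number that more compound is tolerated:
- Compound 1 `CCCCC/C(C)=N/N=C1\SCC(=O)N1Cc1ccc([N+](=O)[O-])cc1`: 35 ug/mL
- Compound 2 `CC(C)=N/N=C1\SCC(=O)N1CN1C(=O)c2ccccc2C1=O`: 22 ug/mL

Only these two numbers are available in this assay. Compound 1 stands at 35 ug/mL and compound 2 at 22 ug/mL, and the two lie within the scatter of each other, so they do not separate the compounds.

The next compound to be tested is compound 3 `O=C1CS/C(=N\N=C2CCCC2)N1Cc1ccc([N+](=O)[O-])cc1`, which keeps the core of compound 1 and changes one place. The change is a group of 6 heavy atoms (5 carbon, 1 nitrogen; one five-membered non-aromatic ring of carbon only) in place of a group of 8 heavy atoms (7 carbon, 1 nitrogen; no ring), on a double-bonded nitrogen. In words, a group of 8 heavy atoms with no ring gives way to a smaller group holding one five-membered non-aromatic ring of carbon only, and it sits on a double-bonded nitrogen.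

Within the data shown here, no pair of measured compounds shows a change of this kind, so the data offer no direct guide to its size. With nothing to suggest a direction, no shift beyond the scatter is expected in this assay. The expected 1.2-fold lower number from compound 1 to compound 3 (0.07 log units; within the scatter) is small. For compound 3 the estimated value is 30 ug/mL, with an expected range from 14 ug/mL to 62 ug/mL.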

Compound 3, half-maximal cytotoxic concentration: 28 ug/mL
For compound 3 the middle estimate is 1.1-fold (0.03 log units) above the measured one, within the range that was stated.
By their numbers in this assay, from the lowest: compounds 2, 3 and 1 (each within the scatter of the next).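

In this assay, the exchange on a double-bonded nitrogen, where a group of 8 heavy atoms with no ring gives way to a smaller group holding one five-membered non-aromatic ring of carbon only, comes with a 1.3-fold lower number from compound 1 to compound 3 (0.10 log units; within the scatter). Among these compounds, this is the first reading of a single change at this place, which the two earlier compounds could not give, and it shows that with the rest of the core of compound 1 kept, the open group and the ring leave the two compounds inseparable in this assay. Nothing at hand explains this result or tells the effect of the smaller size from that of the ring.

A single step cannot show whether the place tolerates any exchange or only groups of carbon like these two, so an amine or a carboxylic acid on the double-bonded nitrogen remains an open case. Whether a longer chain, or a larger carbon ring, would stay within the scatter of compound 1 is open as well.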